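Changing the Aryl Group of Compound 2

This account rests on a few compounds, and the source may have more. Where it says the series, first, only, none or still open, it means among the compounds named here.

Among the measured compounds shown here, in a functional assay on Huh-7 cells (Homo sapiens) for inhibition, read by MTT assay, with a stated time of 48 h (a higher number here means a weaker inhibitor, a lower number a stronger inhibitor), compound 2 `Cc1nnsc1CO/N=C/c1c(C)nn(C)c1Oc1ccc(Br)cc1` gives 11800 nM, the only actual number so far. Compound 1 `Cc1nnsc1CO/N=C/c1c(C)nn(C)c1Oc1cccc(C(F)(F)F)c1` reads > 50000 nM, which is a limit of the assay. Compound 3 `Cc1nnsc1CO/N=C/c1c(C)nn(C)c1Oc1ccc(C(C)(C)C)cc1` reads > 50000 nM, which is also a limit. The series therefore rests largely on (the limit of > 50000 nM in this assay, at which 2 of the 3 values shown sit).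

Compound 4 `Cc1nnsc1CO/N=C/c1c(C)nn(C)c1Oc1cc(F)cc(F)c1` keeps the shared core but carries 3,5-difluorophenyl in place of 4-bromophenyl on an oxygen on an aromatic ring. For the measured compounds named here, only one measured step changes this same aryl group from compound 2. Replacing bromo with tert-butyl gave an at least 4.2-fold higher number from compound 2 to compound 3 (0.62 log units; beyond the scatter), a move toward weaker inhibition that lies beyond the scatter. That step involves a different group, so it is only a rough guide to direction and size. A modest move toward weaker inhibition is expected, and the estimated change is a 1.9-fold higher number from compound 2 to compound 4 (0.27 log units; within the scatter). The estimate for compound 4 is 22000 nM, with an expected range from 8000 nM to 50000 nM.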

Compound 4, half-maximal inhibitory concentration: > 50000 nM
Compound 4: a limit, no number (the forecaster's own chance of this, stated with the estimate: 30%); middle value at least 2.2-fold (0.35 log units) from the limit.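

In this assay, 3,5-difluorophenyl in place of 4-bromophenyl on the oxygen gave an at least 4.2-fold higher number from compound 2 to compound 4 (0.62 log units; beyond the scatter). The earlier step swapped bromo for tert-butyl, and this second change of the aryl group also moves toward weaker inhibition, so the loss is not tied to tert-butyl alone. The reading for compound 4 is a limit, not a number, so the step gives only a minimum, and the series now leans even more heavily on one boundary of the assay: the limit of > 50000 nM in this assay, at which 3 of the 4 values shown sit.

From the compounds shown here alone, the true size of the loss for compound 3 and compound 4 remains unknown, as does whether any aryl group can outperform the 4-bromophenyl of compound 2. Chloro, methoxy or an amine in place of bromo on the aryl ring would test how specific the preference for bromo is.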